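The compounds below may be only part of what the source reports. "The series", "measured", "known", "first", "only" and "open" are said of these compounds alone.

Measured so far in an in vivo functional assay on the whole organism for inhibition, with Rattus norvegicus as the target; a higher number here means that more compound is needed for the effect, a lower number that less compound is needed:
- compound 1 `CCCCc1nc(C)c(CC(=O)N(CC)CC)c(=O)n1Cc1ccc(-c2ccccc2-c2nnn[nH]2)cc1`: 0.089 mg/kg
- compound 2 `CCCCc1nc(C)c(CC(=O)N2CCC[C@H]2C(N)=O)c(=O)n1Cc1ccc(-c2ccccc2-c2nnn[nH]2)cc1`: 0.023 mg/kg
- compound 3 `CCCCc1nc(C)c(CCC(=O)N2CCC[C@H]2C(=O)OC)c(=O)n1Cc1ccc(-c2ccccc2-c2nnn[nH]2)cc1`: 0.063 mg/kg

The position of the ester-bearing compound 3 is set by two steps: a 1.4-fold lower number from compound 1 to compound 3 (0.15 log units; within the scatter), and a 2.7-fold higher number from compound 2 to compound 3 (0.44 log units; beyond the scatter). It therefore cannot be told apart from one neighbour, while it needs more compound than the other.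

Compound 4 `CCCCc1nc(C)c(CCC(=O)N2CCCC2)c(=O)n1Cc1ccc(-c2ccccc2-c2nnn[nH]2)cc1` has not yet been measured. The change is hydrogen in place of methoxycarbonyl on a saturated ring carbon, which leaves a plain pyrrolidin-1-yl on the carbonyl.

For the measured compounds named here, no measured step makes exactly this change, so the guidance is indirect. The closest comparison is a 1.4-fold lower number from compound 1 to compound 3 (0.15 log units; within the scatter), where an amide without a ring ester and one with it stay within the scatter, although the chain changes as well. A substituent on the ring did matter in a 3.9-fold lower number from compound 1 to compound 2 (0.59 log units; beyond the scatter), but that substituent was a carbamoyl group, which neither compound 3 nor compound 4 carries. Together these suggest little change in this assay, with any drift towards a higher number. The expected step is a 1.3-fold higher number from compound 3 to compound 4 (0.10 log units; within the scatter). Compound 4 is estimated at 0.08 mg/kg, with an expected range from 0.03 mg/kg to 0.22 mg/kg.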

Compound 4, dose for half-maximal effect: 0.206 mg/kg
Estimate against measurement, compound 4: 2.6-fold (0.41 log units) below, within the range that was stated.
By their numbers in this assay, from the lowest: compound 2; then compounds 3 and 1 (each within the scatter of the next); then compound 4.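

Taking the methoxycarbonyl group off the saturated ring carbon of compound 3 moves the number in this assay beyond the scatter (a 3.3-fold higher number from compound 3 to compound 4 (0.51 log units; beyond the scatter)), so this ring carbon is not an indifferent place and the gain seen with a ring substituent is not confined to the carbamoyl group of compound 2. Compound 4, with its plain pyrrolidin-1-yl, now needs the most compound of the four, as its steps from the two shorter-chain amides show (a 2.3-fold higher number from compound 1 to compound 4 (0.36 log units; beyond the scatter); a 9.0-fold higher number from compound 2 to compound 4 (0.95 log units; beyond the scatter)), although those two steps also change the chain, so they are less clean than the step from the ester. No measurement at hand accounts for the effect of the ester.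

As far as these compounds go, how a carboxylic acid or a hydroxymethyl group on the same ring carbon would compare remains open, and so does whether the ester itself or simply any group at that carbon lowers the number. The compounds shown also leave open how the opposite arrangement at that ring carbon would behave.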